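The source may report more compounds than this note shows. Statements on the series, on what has been measured and on what is new or still open speak of the compounds shown alone.

In a functional assay on MCF7 cells (Homo sapiens) for inhibition, read by sulforhodamine B assay, with a stated time of 72 h (a higher number here means a weaker inhibitor, a lower number a stronger inhibitor), three compounds have been measured:
compound 1 `Cc1ccc(C2=Nn3c(nnc3C(C)c3ccc(CC(C)C)cc3)SC2)cc1` gives 6300 nM
compound 2 `COc1ccc2cc(C(C)c3nnc4n3N=C(c3ccc([N+](=O)[O-])cc3)CS4)ccc2c1` gives 18800 nM
compound 3 `CC(c1ccc(-c2ccccc2)c(F)c1)c1nnc2n1N=C(c1ccc(OC(F)(F)F)cc1)CS2` gives 4800 nM

Compound 2 stands highest of the three numbers, so it is the weakest inhibitor among them, with its nearest neighbour compound 1 and compound 3 further off, both beyond the scatter. Compound 1 and compound 3 lie within the scatter of each other. Compound 4 `COc1ccc2cc(C(C)c3nnc4n3N=C(c3ccc(OC(F)(F)F)cc3)CS4)ccc2c1` has not been measured. It differs from compound 2 in one place: trifluoromethoxy in place of nitro on an aromatic carbon. Among the compounds with values here, no measured pair shows this change alone. Because compound 3 carries the same trifluoromethoxy-bearing ring and gives 4800 nM, the step of a 2.4-fold lower number from compound 2 to compound 4 (0.37 log units; beyond the scatter) is expected to lower the number moderately, beyond the scatter. Compound 4 is therefore estimated at 8000 nM, within a range from 2500 nM to 25000 nM.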

Compound 4, half-maximal inhibitory concentration: 8800 nM
The estimate for compound 4 lay 1.1-fold (0.04 log units) below the measured number, and the stated range covers the measured number.
By their numbers in this assay, from the lowest: compounds 3, 1 and 4 (each within the scatter of the next); then compound 2.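

In this assay, within the data shown here, the change on this aromatic carbon, para to a large group, gives a 2.1-fold lower number from compound 2 to compound 4 (0.33 log units; beyond the scatter), the first reading of this position with the rest of the molecule held fixed. It shows that the number responds to the group placed here, though only modestly for this swap. Nothing measured here explains the step.

Going by these compounds, whether the same swap gives a similar step with another group on the other side of the shared core stays open. So does how an amine or a carboxylic acid would read at this position.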